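The source may report more compounds than this note shows. Statements on the series, on what has been measured and on what is new or still open speak of the compounds shown alone.

Measured so far:
compound 1 `CCC1CCC(c2nc(C(F)(F)F)ccc2CNC(=O)C(C)c2ccc(NS(C)(=O)=O)c(F)c2)CC1` — 0.3 nM
compound 2 `C[C@H](C(=O)NCc1ccc(C(F)(F)F)nc1C1=CCC(C)(C)CC1)c1ccc(NS(C)(=O)=O)c(F)c1` — 0.1 nM

In an assay on CHO cells for antagonist activity at transient receptor potential cation channel subfamily V member 1 (Homo sapiens), read by FLIPR and calcium flux (a higher number here means a weaker inhibitor, a lower number a stronger inhibitor), compound 1 gives 0.3 nM, the higher of the two numbers shown. Compound 2 gives 0.1 nM, and the gap between these two values lies beyond the usual scatter. Compound 3 `CCC/C=C\c1nc(C(F)(F)F)ccc1CNC(=O)C(C)c1ccc(NS(C)(=O)=O)c(F)c1` has not yet been measured. It differs from compound 1 by pent-1-en-1-yl in place of 4-ethylcyclohexyl on an aromatic carbon. Going by the values given here, no step of this kind has been measured, so its size is open. For compound 3 the expectation is a weaker inhibitor than compound 1, by a modest step beyond the scatter. The estimated value for compound 3 is 1 nM, in the range 0.3 nM to 4 nM, an expected step of a 3.3-fold higher number from compound 1 to compound 3 (0.52 log units; beyond the scatter).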

Compound 3, inhibition constant: 2.1 nM
For compound 3 the middle estimate is 2.1-fold (0.32 log units) below the measured one; measured number inside the range.
By their numbers in this assay, from the lowest: compound 2; then compound 1; then compound 3.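

In this assay, pent-1-en-1-yl in place of 4-ethylcyclohexyl on this aromatic carbon, next to the ring nitrogen, gives a 7.0-fold higher number from compound 1 to compound 3 (0.85 log units; beyond the scatter) as a weaker inhibitor. A carbon ring at this position is therefore not required for activity, though the open chain costs a modest step in this one pair. Nothing available explains the step.

Still open, from the compounds shown here alone, is whether a saturated pentyl chain or an unsubstituted cyclohexyl group would read closer to compound 1 or compound 3. Going by these compounds, the effect of an amine such as piperidine at this position also remains open.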